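Working notes: replacing the thioester side chain of compound 2

This account rests on a few compounds, and the source may have more. Where it says the series, first, only, none or still open, it means among the compounds named here.

Measured in a functional assay on BXPC-3 cells (Homo sapiens) for antiproliferative activity, read by sulforhodamine B assay, with a stated time of 72 h; a lower number here means a stronger inhibitor, a higher number a weaker inhibitor:
- compound 1 `CCCSC(=O)COC(=O)C1=C2C(=NC1=O)c1cccc3cccc2c13` gives 10100 nM
- compound 2 `C=CCSc1ccc2c3c(cccc13)C1=NC(=O)C(C(=O)OCC(=O)SCCC)=C12` gives 13700 nM
- compound 3 `CCCSC(=O)COC(=O)C1=C2C(=NC1=O)c1cccc3c(SCCC)ccc2c13` gives 56300 nM

Among these three numbers, compound 2 has its smallest gap in the step (a 1.4-fold higher number from compound 1 to compound 2 (0.13 log units; within the scatter)) and its widest in the step (a 4.1-fold higher number from compound 2 to compound 3 (0.61 log units; beyond the scatter)). Compound 4 `C=CCSc1ccc2c3c(cccc13)C1=NC(=O)C(C(=O)OCC)=C12` is the next entry, and the change is at the ester (methyl in place of (propylsulfanyl)carbonyl on a saturated chain carbon bound to an oxygen next to a carbonyl group). Read one bond further out, this is (((propylsulfanyl)carbonyl)methoxy)carbonyl to ethoxycarbonyl, with the allylsulfanyl group unchanged.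

Among the measured compounds shown here, no measured step bears directly on this change. Compounds 1, 2 and 3 all carry the (propylsulfanyl)carbonyl group, so the data do not show what its loss does. The three steps concern the sulfanyl substituent on the aromatic carbon, and the largest of them (a 5.6-fold higher number from compound 1 to compound 3 (0.75 log units; beyond the scatter)) gives only a rough idea of how far numbers move in this small series. In this assay a modest step at most is therefore expected, with no firm direction. The expected step is a 1.5-fold higher number from compound 2 to compound 4 (0.16 log units; within the scatter) and remains a weakly supported estimate. For compound 4 the estimated value is 20000 nM with an expected range from 6000 nM to 60000 nM pending measurement.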

Compound 4, half-maximal inhibitory concentration: 2500 nM
Estimate against measurement, compound 4: 8.0-fold (0.90 log units) above, outside the stated range (below it).
By their numbers in this assay, from the lowest: compound 4; then compounds 1 and 2 (each within the scatter of the next); then compound 3.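

In this assay, the ester is a position where the number moves clearly: a 5.5-fold lower number from compound 2 to compound 4 (0.74 log units; beyond the scatter), with methyl in place of (propylsulfanyl)carbonyl on a saturated chain carbon bound to an oxygen next to a carbonyl group. Among the compounds shown here, compounds 1, 2 and 3 all carry the (propylsulfanyl)carbonyl group and differ only at the aromatic carbon, so only this pair shows that, with allylsulfanyl unchanged, the simpler ethoxycarbonyl group gives a lower number than the (((propylsulfanyl)carbonyl)methoxy)carbonyl group it replaces. No supporting data are available to explain this step.

On these data alone, the reading rests on one pair, so it remains open whether the same change would lower the number with hydrogen, as in compound 1, or propylsulfanyl, as in compound 3, on the aromatic carbon. The compounds shown also leave open which part of the departing side chain accounts for the step, and how a carboxylic acid, an amide, a longer alkyl ester or an oxygen ester in place of the thioester would read at this position.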